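Notes on the aryl change from compound 2 to compound 4

This account rests on a few compounds, and the source may have more. Where it says the series, first, only, none or still open, it means among the compounds named here.

Compound 2 `Oc1cc(C(F)(F)F)ccc1-c1nc(-c2ccccc2O)n(-c2ccc(OC(F)(F)F)cc2)n1` gives 84.9% in a functional assay on PC-12 cells (Rattus norvegicus) for cytotoxicity, read by MTT assay, with stated times of 2 h and 24 h, tested at 5 uM; a lower number here means a weaker effect, a higher number a stronger effect of the compound at the concentration tested. Among the three measured numbers it stands second highest; compound 1 `Oc1cc(C(F)(F)F)ccc1-c1nc(-c2ccccc2O)n(-c2ccc(Cl)cc2)n1` gives 87.3%, the nearest value, and compound 3 `Oc1cc(C(F)(F)F)ccc1-c1nc(-c2ccccc2O)n(-c2ccccc2C(F)(F)F)n1` gives 80%, the furthest. Compound 4 `Oc1cc(C(F)(F)F)ccc1-c1nc(-c2ccccc2O)n(-c2ccc(F)cc2F)n1` carries a different group on an aromatic nitrogen: 2,4-difluorophenyl in place of 4-(trifluoromethoxy)phenyl on an aromatic nitrogen. Two measured steps change the group at the same place, a number 7.3 percentage points lower from compound 1 to compound 3 (within the scatter) and a number 4.9 percentage points lower from compound 2 to compound 3 (within the scatter); the third, a number 2.4 percentage points lower from compound 1 to compound 2 (within the scatter), alters a substituent on that group. All three are within the scatter, so no step beyond the scatter is expected for a number 1.9 percentage points lower from compound 2 to compound 4 (within the scatter). Compound 4 is therefore estimated at 83%, within 72% to 92%.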

Compound 4, a percentage reported as activity, at one concentration (the size of the read-out at that concentration, not a potency): 83.5%
The estimate for compound 4 lay 0.5 percentage points below the measured number; the measured number falls inside the stated range.
By their numbers in this assay, from the lowest: compounds 3, 4, 2 and 1 (each within the scatter of the next).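

In this assay the new steps are a number 1.4 percentage points lower from compound 2 to compound 4 (within the scatter) and a number 3.5 percentage points higher from compound 3 to compound 4 (within the scatter) and a number 3.8 percentage points lower from compound 1 to compound 4 (within the scatter), so 2,4-difluorophenyl on the aromatic nitrogen reads like the three aryl groups before it. This group has no hydrogen-bond acceptor and fewer heavy atoms than 4-(trifluoromethoxy)phenyl, yet the two compounds do not separate. No measurement available here bears on why the numbers stay together.

From the compounds shown here alone, whether an amine or a carboxylic acid on this aryl group, or a longer alkyl chain in its place, would move the number stays open.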